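From chloro to methoxy in the series

The compounds below may be only part of what the source reports. "The series", "measured", "known", "first", "only" and "open" are said of these compounds alone.

In a functional assay on CHO cells (Homo sapiens) for antiproliferative activity against CHO (Cricetulus griseus), read by sulforhodamine B assay, with a stated time of 48 h (a higher number here means a weaker inhibitor, a lower number a stronger inhibitor), compound 1 `Cc1cccc(NS(=O)(=O)c2ccc(N3CCNC3=O)cc2)c1` gives 230 nM and compound 2 `O=C1NCCN1c1ccc(S(=O)(=O)Nc2cccc(Cl)c2)cc1` gives 96 nM, the lower of the two numbers. Compound 3 `COc1cccc(NS(=O)(=O)c2ccc(N3CCNC3=O)cc2)c1` has not yet been measured. It differs from compound 2 by methoxy in place of chloro on an aromatic carbon, meta to a large group: methoxy in place of chloro on an aromatic carbon. Going by the values given here, only one measured step bears on this change: a 2.4-fold lower number from compound 1 to compound 2 (0.38 log units; beyond the scatter), a modest step with chloro in place of methyl. Among the compounds with values here, no methoxy compound has been measured, so the size of the next step rests on that single comparison. A similarly modest move to a higher number is expected in this assay, with an estimated step of a 2.1-fold higher number from compound 2 to compound 3 (0.32 log units; beyond the scatter). For compound 3 the expected value is 200 nM, with an estimated range of 85 nM to 470 nM.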

Compound 3, half-maximal inhibitory concentration: 330 nM
Beside the measured number, compound 3's estimate is 1.7-fold (0.22 log units) below it; the measured number falls inside the stated range.
By their numbers in this assay, from the lowest: compound 2; then compounds 1 and 3 (each within the scatter of the next).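

In this assay, going by these compounds alone, the change from 3-chlorophenyl to 3-methoxyphenyl gives a 3.4-fold higher number from compound 2 to compound 3 (0.54 log units; beyond the scatter), and with the earlier step from methyl this leaves chloro as the only one of the three groups with a number clearly apart from the others at this position. Methoxy and methyl are not told apart here, with a 1.4-fold higher number from compound 1 to compound 3 (0.16 log units; within the scatter), so this pair shows no dependence on which of the two groups is present. Nothing available explains why chloro stands apart from methyl and methoxy.

The compounds shown leave open whether the lower number belongs to chloro alone or extends to other halogens such as fluoro or bromo, or to a trifluoromethyl group. They also leave open how an amine or a carboxylic acid would read at this same position.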